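The step from compound 3 to compound 4

A few compounds are considered here, and "the series" means these few. Any claim that something is new, unique, unknown or untested is made for them only; others in the source may bear on it.

In a physicochemical assay for lipophilicity, read by HPLC, at pH 7.5 (on this read-out lower numbers stand for lower lipophilicity and higher numbers for higher lipophilicity), compound 1 `CC[C@@H](Nc1c(C#N)c(-c2ccc(-c3ccc(F)cc3)cc2)nc2cnccc12)C(N)=O` gives 2.7 and compound 2 `CC[C@@H](Nc1c(C#N)c(-c2ccc(-c3ccc(OC)cc3)cc2)nc2cnccc12)C(N)=O` gives 2.7. Methoxy in place of fluoro gives no change at the digits printed from compound 1 to compound 2 (within the scatter). Compound 3 `CC[C@@H](Nc1c(C#N)c(-c2ccc(-c3cccnc3C)cc2)nc2cnccc12)C(N)=O` stands lowest of the three at 1.9.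

Compound 4 `CC[C@@H](Nc1c(C#N)c(-c2ccc(-c3ccccc3CO)cc2)nc2cnccc12)C(N)=O` differs from compound 3 as follows: 2-(hydroxymethyl)phenyl in place of 2-methylpyridin-3-yl on an aromatic carbon.

Among the compounds with values here, two steps bear on this change. With 2-methylpyridin-3-yl in place of 4-fluorophenyl, the result is a number 0.80 log units lower from compound 1 to compound 3 (beyond the scatter). With 2-methylpyridin-3-yl in place of 4-methoxyphenyl, it is a number 0.80 log units lower from compound 2 to compound 3 (beyond the scatter). Within the data shown here, compound 4 again has a ring of carbon only, but no measured compound carries 2-(hydroxymethyl)phenyl. A partial reversal of those steps is expected, estimated as a number 0.40 log units higher from compound 3 to compound 4 (beyond the scatter). The expected value for compound 4 is 2.3, with an estimated range of 1.9 to 2.7.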

Compound 4, distribution coefficient: 2.1
For compound 4 the middle estimate is 0.20 log units above the measured one; the range from low to high includes it.
By their numbers in this assay, from the lowest: compounds 3 and 4 (each within the scatter of the next); then compounds 1 and 2 (each within the scatter of the next).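

In this assay, 2-(hydroxymethyl)phenyl and 2-methylpyridin-3-yl cannot be told apart at this position: a number 0.20 log units higher from compound 3 to compound 4 (within the scatter). A ring of carbon only therefore does not by itself return the number to the level of the 4-substituted phenyl groups, as shown by a number 0.60 log units lower from compound 1 to compound 4 (beyond the scatter) and a number 0.60 log units lower from compound 2 to compound 4 (beyond the scatter). No supporting data explain these steps.

The compounds shown leave open whether the lower number follows the hydroxymethyl group itself or its place on the ring. They also leave open how an aminomethyl group or a carboxylic acid would read on this ring.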